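Moving the Fluorine Around the Phenyl Ring

This account rests on a few compounds, and the source may have more. Where it says the series, first, only, none or still open, it means among the compounds named here.

Compound 3 `CCOC(=O)c1cnn(CC(O)CC)c1NC(=O)Nc1ccccc1F` was tested in a functional assay on cells (Neutrophil, Homo sapiens) for inhibition, with a stated time of 10 min (a higher number here means a weaker inhibitor, a lower number a stronger inhibitor), where compound 3 gives 120 nM. Among the two plain numbers shown, this is the highest: compound 2 `CCOC(=O)c1cnn(CC(C)O)c1NC(=O)NCc1ccccc1` gives 15 nM in this assay, and the gap between the two is beyond the scatter, so compound 3 is the weaker inhibitor of the pair. Compound 1 `CCOC(=O)c1cnn(CC(C)O)c1NC(=O)Nc1ccc(F)cc1` gives only a limit in this assay, > 10 nM, and not a number. Among the measured compounds shown here, the one single-point step among the measured compounds, a step that the limit leaves unreadable from compound 1 to compound 2, is thus left unreadable by the limit of > 10 nM in this assay, at which 1 of the 3 values shown sits.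

Compound 4 `CCOC(=O)c1cnn(CC(O)CC)c1NC(=O)Nc1ccc(F)cc1` differs from compound 3 by 4-fluorophenyl in place of 2-fluorophenyl on an amide-type nitrogen. For the measured compounds named here, no measured step concerns this same change. Compound 1 carries the same 4-fluorophenyl group as compound 4, but on a core with a different chain, and its result is a limit, so it offers no direction. The step of a 1.5-fold lower number from compound 3 to compound 4 (0.18 log units; within the scatter) is therefore estimated to be small, with no clear direction, and to lie near the scatter of repeated measurements. Compound 4 is estimated to give 80 nM in this assay, with a likely range from 15 nM to 400 nM.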

Compound 4, half-maximal inhibitory concentration: 3.2 nM
The estimate for compound 4 lay 25-fold (1.40 log units) above the measured number; the whole stated range lies above it.
By their numbers in this assay, from the lowest: compound 4; then compound 2; then compound 3.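

In this assay, 4-fluorophenyl in place of 2-fluorophenyl gives a 38-fold lower number from compound 3 to compound 4 (1.57 log units; beyond the scatter), so two groups with the same atoms, joined differently, are far apart here, and the place of the fluorine on the phenyl ring clearly matters on this core. Among the compounds shown here, none of the earlier pairs changed the place of the fluorine alone, so this size of effect could not be seen from them. On the chain, methyl in place of hydrogen on a saturated chain carbon, two bonds along the chain from an oxygen on a saturated carbon, comes with an at least 3.1-fold lower number from compound 1 to compound 4 (0.49 log units; beyond the scatter), and this size is only a bound because compound 1 rests on a limit: the limit of > 10 nM in this assay, at which 1 of the 4 values shown sits.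

The compounds shown do not tell why the place of the fluorine has so large an effect, and they do not say whether the same change would have the same size on the chain of compound 1. Going by these compounds, it also remains open how a chlorine or a methoxy group in place of the fluorine of compound 4, or a longer chain than the one it carries, would fare.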